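From phenyl to 3,4-dichlorophenyl on compound 1

A few compounds are considered here, and "the series" means these few. Any claim that something is new, unique, unknown or untested is made for them only; others in the source may bear on it.

Compound 1 (`COc1cc(/C(=C/c2ccccc2)C(C)O)cc(OC)c1OC`) gives > 100000 nM in a functional assay on L1210 cells (Mus musculus) for antiproliferative activity, read by MTT assay, with a stated time of 72 h (on this read-out higher numbers stand for weaker inhibition and lower numbers for stronger inhibition), as a limit of the assay, not a number. Compound 1 thus sits at the limit of > 100000 nM in this assay, at which 2 of the 3 values shown sit, and offers no exact starting point.

Compound 4 (`COc1cc(/C(=C/c2ccc(Cl)c(Cl)c2)C(C)O)cc(OC)c1OC`) carries 3,4-dichlorophenyl in place of phenyl on a double-bonded chain carbon bound to a double-bonded chain carbon, and 3,4-dichlorophenyl in place of phenyl on a double-bonded chain carbon bound to a double-bonded chain carbon sets out the count of that change.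

Two relatives bear on it. Among the measured compounds shown here, compound 2 (`COc1cc(/C(=C/c2ccc(C)cc2)C(C)O)cc(OC)c1OC`), with methyl in place of hydrogen on an aromatic carbon, gives 33500 nM in this assay as the only exact number so far. Compound 3 (`COc1cc(/C(=C/c2ccc(Br)cc2)C(C)O)cc(OC)c1OC`), with bromo in place of hydrogen on an aromatic carbon, gives > 100000 nM in this assay as a limit of the assay.

The methyl change shows an at least 2.9-fold lower number from compound 1 to compound 2 (0.47 log units; beyond the scatter) as the one readable gain. The bromo change shows a step that the two limits leave unreadable from compound 1 to compound 3 with no size to take from it. Bromo in place of methyl gives an at least 2.9-fold higher number from compound 2 to compound 3 (0.47 log units; beyond the scatter) and leaves the one measured halogen case without that gain, so compound 4 is expected to gain little.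

The expected step is an at least 1.2-fold lower number from compound 1 to compound 4 (0.09 log units; that floor lies within the scatter) as estimated here, toward a lower number if it can be read at all. For compound 4 the estimated value is 80000 nM within an expected range from 30000 nM to 200000 nM with a real chance of another limit.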

Compound 4, half-maximal inhibitory concentration: 18500 nM
Beside the measured number, compound 4's estimate is 4.3-fold (0.64 log units) above it; the measured number lies below the stated range.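

The change to 3,4-dichlorophenyl in this assay gives an at least 5.4-fold lower number from compound 1 to compound 4 (0.73 log units; beyond the scatter) and an at least 5.4-fold lower number from compound 3 to compound 4 (0.73 log units; beyond the scatter), so among the compounds shown a halogen on the phenyl group does not by itself keep a compound at the limit, although compound 3 stays there. Both of these steps are floors, since compound 1 and compound 3 each carry a limit of the assay and not a number: the limit of > 100000 nM in this assay, at which 2 of the 4 values shown sit. The comparison with the methyl compound gives a 1.8-fold lower number from compound 2 to compound 4 (0.26 log units; within the scatter), so 3,4-dichlorophenyl and 4-methylphenyl cannot be ranked against each other here, and compound 4 joins compound 2 as the second compound with an exact number.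

The compounds shown leave open whether both chlorines are needed for this reading or whether a single one, as in 4-chlorophenyl, would give the same result. They also leave open how a phenyl group carrying an amine or a carboxylic acid would read in this assay, and so whether anything other than methyl and chlorine can bring this series clear of the limit.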